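The source may hold more compounds than are shown below. What is called first, only, known or untested is meant among the compounds shown, and "the series" means these compounds.

Values in a functional assay on DU-145 cells (Homo sapiens) for inhibition, read by trypan blue exclusion, with a stated time of 72 h (a higher number here means a weaker inhibitor, a lower number a stronger inhibitor), for the series so far:
- compound 1 `Cn1c(=O)c(S(=O)(=O)c2ccc(F)cc2F)cc2cnc(Nc3ccc4sccc4c3)nc21` gives 500 nM
- compound 2 `Cn1c(=O)c(S(=O)(=O)c2ccc(F)cc2F)cc2cnc(Nc3ccc4[nH]ncc4c3)nc21` gives 30000 nM
- compound 3 `Cc1ccc(S(=O)(=O)c2cc3cnc(Nc4ccc5cc[nH]c5c4)nc3n(C)c2=O)cc1` gives 15000 nM

Compound 3 sits second highest of the three numbers. Its value lies within the scatter of that of compound 2 and well above that of compound 1, and the gap to compound 1 is beyond the scatter.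

The next compound is compound 4 `Cn1c(=O)c(S(=O)(=O)c2ccc(F)cc2F)cc2cnc(Nc3ccc4cc[nH]c4c3)nc21`, and the change from compound 3 is 2,4-difluorophenyl in place of 4-methylphenyl on a sulfonyl sulfur in a single place: 2,4-difluorophenyl in place of 4-methylphenyl on a sulfonyl sulfur.

Going by the values given here, the only measured single-place step is a 60-fold higher number from compound 1 to compound 2 (1.78 log units; beyond the scatter) and it is large, but it concerns the group on the nitrogen and leaves the sulfonyl group untouched. It therefore says little about this change. Among the compounds with values here, no measured pair isolates a change on the sulfonyl sulfur, and compound 2 and compound 3 differ in more than one place. The expectation therefore starts from compound 3 at 15000 nM and assumes no clear shift in either direction.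

The expected step is a 1.3-fold lower number from compound 3 to compound 4 (0.10 log units; within the scatter) and is not expected to go beyond the scatter.

For compound 4 the estimated value is 12000 nM with an expected range from 3000 nM to 40000 nM in this series.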

Compound 4, half-maximal inhibitory concentration: 5000 nM
Compound 4: the middle estimate sits 2.4-fold (0.38 log units) above what was measured; low and high end bracket the measured number.
By their numbers in this assay, from the lowest: compound 1; then compound 4; then compounds 3 and 2 (each within the scatter of the next).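

In this assay, going by these compounds alone, the aryl group on the sulfonyl sulfur proves able to move the number: 2,4-difluorophenyl in place of 4-methylphenyl gives a 3.0-fold lower number from compound 3 to compound 4 (0.48 log units; beyond the scatter), the first measured pair to isolate a change at this place, and the step lies beyond the scatter. With 2,4-difluorophenyl held constant, the group on the nitrogen can now be read at three points, as 1H-indol-6-yl in place of 1H-indazol-5-yl gives a 6.0-fold lower number from compound 2 to compound 4 (0.78 log units; beyond the scatter) and 1H-indol-6-yl in place of 1-benzothiophen-5-yl gives a 10-fold higher number from compound 1 to compound 4 (1.00 log units; beyond the scatter), which places 1H-indol-6-yl between the other two groups in this assay, with 1-benzothiophen-5-yl giving the lowest number. Nothing available accounts for any of these steps.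

Going by these compounds, the step on the sulfonyl sulfur rests on a single pair carrying 1H-indol-6-yl, so whether it carries over to 1-benzothiophen-5-yl or 1H-indazol-5-yl on the nitrogen stays open. Also open, on these data alone, is how the number would read with an unsubstituted phenyl, or with a phenyl carrying an amine or a carboxylic acid, on the sulfonyl sulfur.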